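Reading a step when every value is a limit

This account rests on a few compounds, and the source may have more. Where it says the series, first, only, none or still open, it means among the compounds named here.

Measured so far in an ADME assay on HEK293 cells (Homo sapiens) for cytotoxicity; a lower number here means a stronger inhibitor, a higher number a weaker inhibitor:
compound 1 `CCC(=O)N1C[C@H](NC(=O)c2ccc(-n3ccccc3=O)cc2)[C@H](NC(=O)c2ccc(Cl)s2)C1`: > 100000 nM
compound 2 `CC(C)C(=O)N1C[C@H](NC(=O)c2ccc(-n3ccccc3=O)cc2)[C@H](NC(=O)c2ccc(Cl)s2)C1`: > 100000 nM
compound 3 `O=C(N[C@H]1CN(C(=O)c2ccccc2)C[C@H]1NC(=O)c1ccc(Cl)s1)c1ccc(-n2ccccc2=O)cc1`: > 100000 nM

Compound 3 gives > 100000 nM, which is a limit of the assay and not a number. All three measured compounds stand at the limit of > 100000 nM in this assay, at which 3 of the 3 values shown sit, so compound 3 has no exact place among them.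

Compound 4 `COCC(=O)N1C[C@H](NC(=O)c2ccc(-n3ccccc3=O)cc2)[C@H](NC(=O)c2ccc(Cl)s2)C1` differs from compound 3 at one spot: methoxymethyl in place of phenyl on a carbonyl carbon. Put simply, this is methoxymethyl in place of phenyl on a carbonyl carbon.

Two measured steps change the group on that same carbonyl carbon: a step that the two limits leave unreadable from compound 1 to compound 3 and a step that the two limits leave unreadable from compound 2 to compound 3. A third is a step that the two limits leave unreadable from compound 1 to compound 2. For the measured compounds named here, none of the three has a readable size, yet ethyl, isopropyl and phenyl all leave the result at the limit, and no measured compound goes against this.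

The expected outcome in this assay is a number no higher from compound 3 to compound 4 (the limit leaves the size open), meaning no change beyond the scatter. For compound 4 the estimate is 100000 nM, with an expected range from 50000 nM to 200000 nM.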

Compound 4, half-maximal inhibitory concentration: > 100000 nM
Compound 4: no number, only a limit (the forecaster's own chance of this, stated with the estimate: 90%); the middle value lies on the limit itself.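

In this assay compound 4 gives > 100000 nM as a limit of the assay and not a number. No new step can be read among compound 1, compound 2, compound 3 and compound 4, because all four share one limit: the limit of > 100000 nM in this assay, at which 4 of the 4 values shown sit.

The compounds shown leave open how far each lies beyond that limit, and whether any group on this carbonyl carbon gives a readable value.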